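The source may hold more compounds than are shown below. What is called first, only, known or untested is meant among the compounds shown, and "the series" means these compounds.

Measured so far:
compound 1, `CC(=O)Oc1ccccc1C1CC(C)=NN1C(=O)CN1CCCCC1`: 4890 nM
compound 2, `O=C(c1ccccc1)N1N=C(c2cc3ccccc3oc2=O)CC1c1ccccc1`: 12700 nM

In a functional assay on MGC-803 cells (Homo sapiens) for cytotoxicity, read by MTT assay, with a stated time of 48 h (a higher number here means a weaker inhibitor, a lower number a stronger inhibitor), compound 2 gives 12700 nM, the higher of the two numbers; compound 1 sits lower by a gap beyond the usual scatter. Compound 3, `CCN(CC)C1CCN(CC(=O)N2N=C(c3cc4ccccc4oc3=O)CC2c2ccccc2)CC1`, is not yet measured. It differs from compound 2 in one place: (4-(diethylamino)piperidin-1-yl)methyl in place of phenyl on a carbonyl carbon. Among the compounds with values here, no step between two measured compounds covers this change. Compound 1, the lower of the pair, also carries a basic ring on the acetyl carbonyl, so a moderate step downward from compound 2 is expected, a 2.5-fold lower number from compound 2 to compound 3 (0.40 log units; beyond the scatter). For compound 3 the expected value in this assay is 5000 nM, with a range of 1500 nM to 15000 nM.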

Compound 3, half-maximal inhibitory concentration: 32400 nM
Compound 3: middle estimate off by 6.5-fold (0.81 log units), on the low side, outside the stated range (above it).
By their numbers in this assay, from the lowest: compound 1; then compound 2; then compound 3.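

In this assay, putting (4-(diethylamino)piperidin-1-yl)methyl in place of phenyl on the carbonyl carbon gives a 2.6-fold higher number from compound 2 to compound 3 (0.41 log units; beyond the scatter). This one-place comparison shows that, with the rest of compound 2 unchanged, this larger group with a non-aromatic ring and two hydrogen-bond acceptors gives a weaker inhibitor than phenyl. No measurement at hand accounts for the step. As far as these compounds go, it remains open whether a plain methyl or a dimethylaminomethyl on the same carbonyl carbon would read closer to phenyl or to (4-(diethylamino)piperidin-1-yl)methyl.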